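Oxolan-3-yl in place of cyclobutyl on an amine nitrogen

The compounds below may be only part of what the source reports. "The series", "measured", "known", "first", "only" and "open" are said of these compounds alone.

In a functional assay on SK-OV-3 cells (Homo sapiens) for inhibition, read by CCK-8 assay, with a stated time of 70 h (on this read-out higher numbers stand for weaker inhibition and lower numbers for stronger inhibition), compound 3 (`c1ccc(COc2ccc(OCCOCCNC3CCC3)cc2)cc1`) gives 25000 nM and compound 1 (`c1ccc(COc2ccc(OCCOCCNC3CCCC3)cc2)cc1`) gives 24800 nM as its value, so the two stand together within the scatter. Compound 2 (`c1ccc(COc2ccc(OCCOCCNc3ccccc3)cc2)cc1`) reads > 100000 nM as a limit of the assay and not a number.

Compound 4 (`c1ccc(COc2ccc(OCCOCCNC3CCOC3)cc2)cc1`) carries oxolan-3-yl in place of cyclobutyl on an amine nitrogen. Among the measured compounds shown here, no measured compound has a ring oxygen, so this change is untested. Going by the flat step a 1.0-fold higher number from compound 1 to compound 3 (0.00 log units; within the scatter) between saturated rings, no step beyond the scatter is expected in this assay for this change. The step of an at least 4.0-fold lower number from compound 2 to compound 3 (0.60 log units; beyond the scatter) shows that the group on the nitrogen can matter, which leaves room for a drift to a higher number. The expected step is small (a 1.3-fold higher number from compound 3 to compound 4 (0.12 log units; within the scatter)). The estimated value for compound 4 is 33000 nM with an expected range from 16000 nM to 80000 nM for a single measurement.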

Compound 4, half-maximal inhibitory concentration: 48000 nM
Compound 4: middle estimate off by 1.5-fold (0.16 log units), on the low side; the measured number falls inside the stated range.
By their numbers in this assay, from the lowest: compounds 1, 3 and 4 (each within the scatter of the next). At a limit, above all of these: compound 2.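

Oxolan-3-yl on this amine nitrogen stays within the scatter of both saturated carbon rings in this assay: a 1.9-fold higher number from compound 3 to compound 4 (0.28 log units; within the scatter) and a 1.9-fold higher number from compound 1 to compound 4 (0.29 log units; within the scatter). The second step keeps a five-membered ring and brings in one oxygen and one hydrogen-bond acceptor, and no change beyond the scatter is seen with them. The oxolan-3-yl compound also stays apart from the phenyl compound, an at least 2.0-fold lower number from compound 2 to compound 4 (0.31 log units; beyond the scatter), so the gap seen earlier for the carbon rings extends to this ring; compound 2 stands at a limit and not a number: the limit of > 100000 nM in this assay, at which 1 of the 4 values shown sits.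

As far as these compounds go, it remains open whether a nitrogen-containing ring such as piperidin-4-yl, or an open chain such as isopropyl, would keep these values. From the compounds shown here alone, it also remains open whether benzyl, with its aromatic ring set one carbon further out, would read like phenyl or like the saturated rings.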